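This account rests on a few compounds, and the source may have more. Where it says the series, first, only, none or still open, it means among the compounds named here.

Values in an ADME assay on L6 cells (Rattus norvegicus) for cytotoxicity (on this read-out lower numbers stand for stronger inhibition and higher numbers for weaker inhibition), so far
Compound 1 `Cc1ccc(S(=O)(=O)N2c3ccccc3CCC2C)cc1` gives 4900 nM
Compound 2 `CC1CCc2ccccc2N1S(=O)(=O)c1ccc([N+](=O)[O-])cc1` gives 248000 nM
Compound 3 `CC1CCc2ccccc2N1S(=O)(=O)c1cccc([N+](=O)[O-])c1` gives 187000 nM

Compound 2 and compound 3 lie within the scatter of each other, and compound 1 has a far lower number than either. Next is compound 4 (`CC1CCc2ccccc2N1S(=O)(=O)c1ccc(N)cc1`), with amino in place of nitro on an aromatic carbon, para to a large group: amino in place of nitro on an aromatic carbon. Going by the values given here, one measured step bears on this place, a 51-fold higher number from compound 1 to compound 2 (1.70 log units; beyond the scatter), a large step with nitro in place of methyl. Amino has not been measured in this series, so only the direction carries over: a lower number is expected in this assay, by a step probably smaller than that one. The estimated change is an 8.3-fold lower number from compound 2 to compound 4 (0.92 log units; beyond the scatter). For compound 4 the expected value is 30000 nM, with an estimated range of 6000 nM to 150000 nM.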

Compound 4, half-maximal inhibitory concentration: 35300 nM
Compound 4: middle estimate off by 1.2-fold (0.07 log units), on the low side; low and high end bracket the measured number.
By their numbers in this assay, from the lowest: compound 1; then compound 4; then compounds 3 and 2 (each within the scatter of the next).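

Amino in place of nitro, para to a large group, gives a 7.0-fold lower number from compound 2 to compound 4 (0.85 log units; beyond the scatter) in this assay, so this position does not respond only to a change away from methyl. Amino in place of methyl still gives a 7.2-fold higher number from compound 1 to compound 4 (0.86 log units; beyond the scatter), which places amino between the other two groups, with all three separated beyond the scatter. No measurement available here explains this order. Open, on these data alone, is where a methoxy group, a chlorine atom or an acetamide would fall at this position, and how amino would read at the nitro position of compound 3.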